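A few compounds are considered here, and "the series" means these few. Any claim that something is new, unique, unknown or untested is made for them only; others in the source may bear on it.

Measured in a physicochemical assay for solubility, measured as kinetic solubility, at pH 7.4; on this read-out higher numbers stand for higher solubility and lower numbers for lower solubility:
- Compound 1 `COc1cc(N2CCNCC2)ccc1Nc1nc(NC2CCCCC2)c2nc[nH]c2n1`: 19000 nM
- Compound 2 `COc1cc(N2CCN(C(=O)C3CCC(O)CC3)CC2)ccc1Nc1nc(NC2CCCCC2)c2nc[nH]c2n1`: 19000 nM
- Compound 3 `COc1cc(N2CCC(C(=O)N3CCC(N(C)C)C3)CC2)ccc1Nc1nc(NC2CCCCC2)c2nc[nH]c2n1`: 38000 nM

All three compounds share one core and differ in the group carried on the saturated ring attached to it. In this assay, compound 3 gives 38000 nM, a value within the usual scatter of both compound 1 and compound 2.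

Compound 4 `COc1cc(N2CCC(CC(=O)N3CCN(C)CC3)CC2)ccc1Nc1nc(NC2CCCCC2)c2nc[nH]c2n1` has not yet been measured. It carries ((4-methylpiperazin-1-yl)carbonyl)methyl in place of (3-(dimethylamino)pyrrolidin-1-yl)carbonyl on a saturated ring carbon. The two compounds are made of the same atoms, joined differently.

For the measured compounds named here, only one measured step offers any guide: no change at the digits printed from compound 1 to compound 2 (within the scatter). There, (4-hydroxycyclohexyl)carbonyl replaces hydrogen on an amine nitrogen in a ring. Going by the values given here, that is a different change at a different place, so it bears on this exchange only loosely, and no measured pair tests the exchange directly. Still, the three measured values sit close together despite quite different groups, so no shift beyond the scatter is expected in this assay.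

The expected step is a 1.4-fold lower number from compound 3 to compound 4 (0.13 log units; within the scatter), an estimate that stays within the scatter. For compound 4 the estimated value is 28000 nM, with an expected range from 13000 nM to 55000 nM.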

Compound 4, solubility: 38000 nM
Beside the measured number, compound 4's estimate is 1.4-fold (0.13 log units) below it, within the range that was stated.
By their numbers in this assay, from the lowest: compounds 1, 2, 3 and 4 (each within the scatter of the next).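

In this assay, putting ((4-methylpiperazin-1-yl)carbonyl)methyl in place of (3-(dimethylamino)pyrrolidin-1-yl)carbonyl gives no change at the digits printed from compound 3 to compound 4 (within the scatter), so this exchange leaves the read-out unmoved. Among the compounds shown, this is the only step at this place, on a saturated ring carbon three ring bonds from the ring nitrogen, whereas the earlier step was on an amine nitrogen in a ring. It shows that a five-membered non-aromatic ring with 1 hetero atom can give way to a six-membered non-aromatic ring with 2 hetero atoms, built from the same atoms, with no shift beyond the scatter, though nothing measured here explains this result.

This single pair cannot show whether the position tolerates change in general, since both groups contain a ring amine and a carbonyl. A carboxylic acid, a simple hydroxyl or a longer chain on the same ring carbon might give a different number, and the compounds shown leave that question open.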